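This account rests on a few compounds, and the source may have more. Where it says the series, first, only, none or still open, it means among the compounds named here.

Among the compounds with values here, compound 2 `CCOc1cnc(CS(=O)(=O)/C=C/c2c(OC)cc(OC)cc2OC)cn1` is the only member of this set with a number in a functional assay on HCT-116 cells (Homo sapiens) for antiproliferative activity, read by MTT assay, with a stated time of 72 h (a lower number here means a stronger inhibitor of growth, a higher number a weaker inhibitor of growth), where compound 2 gives 1280 nM. Compound 1 `COc1cc(OC)c(/C=C/S(=O)(=O)Cc2cnc(Cl)cn2)c(OC)c1` stands only at a limit of this assay, > 10000 nM, and so gives no number. Within the data shown here, the one measured step, an at least 7.8-fold lower number from compound 1 to compound 2 (0.89 log units; beyond the scatter), rests on that limit of > 10000 nM in this assay, at which 1 of the 2 values shown sits, and is therefore known only as a lower bound. Compound 3 `COc1cc(OC)c(/C=C/S(=O)(=O)Cc2nc(N)ncc2OC)c(OC)c1` differs from compound 2 by 2-amino-5-methoxypyrimidin-4-yl in place of 5-ethoxypyrazin-2-yl on a saturated chain carbon bound to a sulfonyl sulfur. The measured step changed a single substituent on the ring; the step to compound 3 exchanges the whole ring, so the measured step bears on it only loosely. Against that background, compound 3 is expected to stay within a modest distance of compound 2, with the step of a 1.6-fold higher number from compound 2 to compound 3 (0.19 log units; within the scatter) expected to fall near or within the usual scatter. Compound 3 is accordingly estimated at 2000 nM in this assay, within the range 500 nM to 8000 nM.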

Compound 3, concentration for 50% growth inhibition: > 10000 nM
Compound 3 gave a limit, no number (the forecaster's own chance of this, stated with the estimate: 20%); middle value at least 5.0-fold (0.69 log units) from the limit.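

Exchanging the whole ring on a saturated chain carbon bound to a sulfonyl sulfur is not a neutral change in this assay: 2-amino-5-methoxypyrimidin-4-yl in place of 5-ethoxypyrazin-2-yl gives an at least 7.8-fold higher number from compound 2 to compound 3 (0.89 log units; beyond the scatter). Compound 3 stands at a limit of the assay, > 10000 nM, and not at a number. Compound 2 therefore remains the only compound with a number, and the step between compound 1 and compound 3 cannot be read, since both rest on the same limit: the limit of > 10000 nM in this assay, at which 2 of the 3 values shown sit.

The compounds shown leave open whether the amino group, the methoxy in place of ethoxy or the change of ring carries the step from compound 2. As far as these compounds go, how a propoxy group or an amine in place of the ethoxy of compound 2 would read also stays open.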